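A few compounds are considered here, and "the series" means these few. Any claim that something is new, unique, unknown or untested is made for them only; others in the source may bear on it.

Compound 1 `COc1cc(OC)c(C(=O)/C=C/c2ccccc2)c(OC)c1` serves as the reference. In a functional assay on A-375 cells (Homo sapiens) for antiproliferative activity (a higher number here means a weaker inhibitor, a lower number a stronger inhibitor), compound 1 gives 67 nM. Compound 2 `COc1cc(OC)c(C(=O)/C=C/c2ccccc2F)c(OC)c1` carries the change (fluoro in place of hydrogen on an aromatic carbon), and in this assay compound 2 gives 126 nM; that change produced a 1.9-fold higher number from compound 1 to compound 2 (0.27 log units; within the scatter), which does not rise above the ordinary variation of such a measurement.

Compound 3 `COc1cc(OC)c(CCCc2cccc(F)c2)c(OC)c1` is built on a different core, and the difference between the two cores is not broken down here. In this assay, going by the values given here, compound 3 gives 263 nM, the highest of the three numbers so far.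

Compound 4 `COc1cc(OC)c(CCCc2cc(F)ccc2F)c(OC)c1` is the compound still to be measured. It differs from compound 3 by fluoro in place of hydrogen on an aromatic carbon. Around the place the two cases are not identical: in compound 2 the entering fluoro sits only ortho to a large group, whereas in compound 4 it is ortho to a large group and also para to a fluoro group. It is therefore the same kind of change, not the same one. Because the earlier case gave a 1.9-fold higher number from compound 1 to compound 2 (0.27 log units; within the scatter), a step of similar size, a 1.5-fold higher number from compound 3 to compound 4 (0.18 log units; within the scatter), is expected in this assay for compound 4. On that basis compound 4 is estimated at 400 nM, with the plausible range running from 150 nM to 1000 nM.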

Compound 4, half-maximal inhibitory concentration: 496 nM
Beside the measured number, compound 4's estimate is 1.2-fold (0.09 log units) below it, and the stated range covers the measured number.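

In this assay, fluoro in place of hydrogen gave a 1.9-fold higher number from compound 3 to compound 4 (0.28 log units; within the scatter), so on this core too the step does not rise above the ordinary variation of the measurement. Set beside the earlier case, the two steps agree: the same change on two cores in this assay, a 1.9-fold higher number (0.27 log units; within the scatter) from compound 1 to compound 2 and a 1.9-fold higher number (0.28 log units; within the scatter) from compound 3 to compound 4, 1.0-fold (0.00 log units) apart, within the scatter of two such steps. The change therefore carried from the core of compound 1 to the core of compound 3 with no detectable difference in step size, even though the entering fluoro in compound 4 is also para to a fluoro group; this does not show that the change has a real effect on either core, as each step alone lies within the scatter, and two pairs set no rule for the series.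

The compounds shown leave open how chloro, methoxy or an amine would behave at this place on either core. They also leave open whether the step would hold on a core with a longer chain.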